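The source may report more compounds than this note shows. Statements on the series, on what has been measured and on what is new or still open speak of the compounds shown alone.

Measured compounds, in an in vitro assay on Sf21 cells for inhibition of high affinity 3',5'-cyclic-AMP phosphodiesterase 7A (Homo sapiens); on this read-out higher numbers stand for weaker inhibition and lower numbers for stronger inhibition:
compound 1 `CNc1nc(NC)nc(NC2(C#N)CCCCC2)n1` gives > 1000 nM, a limit of the assay.
compound 2 `CNc1nc(N)nc(NC2(C#N)CCCCC2)n1` gives "not determined" (no result reported).
compound 3 `CNc1nc(Cl)nc(NC2(C#N)CCCCC2)n1` gives 1070 nM.

Among the measured compounds shown here, compound 3 stands as the only single number among the three; compound 1 sits at the limit of > 1000 nM in this assay, at which 1 of the 3 values shown sits, and compound 2 has no result. For the measured compounds named here, the one step within the set, a step that the limit leaves unreadable from compound 1 to compound 3, cannot be read in size for that reason. Compound 4 `CNc1nc(NC2(C#N)CCCCC2)nc(SC)n1` differs from compound 3 by methylsulfanyl in place of chloro on an aromatic carbon. Going by the values given here, no measured step bears on this exchange, so no direction can be drawn from the data. Compound 4 is therefore expected to stay close to compound 3, with a 1.1-fold lower number from compound 3 to compound 4 (0.03 log units; within the scatter) not beyond the scatter. The estimate for compound 4 in this assay is 1000 nM, ranging from 300 nM to 3500 nM.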

Compound 4, half-maximal inhibitory concentration: 46 nM
Compound 4: the middle estimate sits 22-fold (1.34 log units) above what was measured; measured number below the stated range.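

Among the compounds shown here, on an aromatic carbon between two ring nitrogen atoms, this position proves sensitive to the group it carries, which the earlier compounds could not show, since their only step was unreadable: in this assay, methylsulfanyl in place of chloro gives a 23-fold lower number from compound 3 to compound 4 (1.37 log units; beyond the scatter). Methylsulfanyl in place of methylamino gives an at least 21-fold lower number from compound 1 to compound 4 (1.33 log units; beyond the scatter). That step starts from a limit of the assay, not a number: the limit of > 1000 nM in this assay, at which 1 of the 4 values shown sits. The compounds shown leave open whether the sulfur or its methyl carries the change, and whether methoxy or the longer ethylsulfanyl would behave alike.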